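Compound 2 to compound 3: a step from a limit

The source may hold more compounds than are shown below. What is called first, only, known or untested is meant among the compounds shown, and "the series" means these compounds.

Compound 1 `C=C[C@@](C)(/C=C/c1ccc(O)c(CO)c1)CCC=C(C)C` gives > 52000 nM
Compound 2 `C=C[C@@](C)(/C=C/c1ccc(O)c(/C=C(\C)C(=O)OCC)c1)CCC=C(C)C` gives > 52000 nM

In a functional assay on HepG2 cells (Homo sapiens) for cytotoxicity, with a stated time of 72 h (a lower number here means that less compound is needed, a higher number that more compound is needed for the effect), compound 2 gives > 52000 nM as a limit and not a number. Both measured compounds sit at the limit of > 52000 nM in this assay, at which 2 of the 2 values shown sit, and neither has a readable value. Compound 3 `C=C[C@@](C)(/C=C/c1ccc(O)c(/C=C/c2ccc(F)cc2)c1)CCC=C(C)C` differs from compound 2 at one place: 2-(4-fluorophenyl)ethenyl in place of 2-(ethoxycarbonyl)prop-1-en-1-yl on an aromatic carbon and the new group stands on an aromatic carbon, ortho to a hydroxy group. Among the measured compounds shown here, the one measured step at this place is a step that the two limits leave unreadable from compound 1 to compound 2 and it offers no size to carry over. Compound 3 is therefore expected to stay close to the same limit in this assay and any readable step would be expected toward a lower number. The step expected is an at least 1.2-fold lower number from compound 2 to compound 3 (0.09 log units; that floor lies within the scatter) in this estimate. Compound 3 is estimated at 42000 nM with an expected range from 15000 nM to 90000 nM in repeated measurement.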

Compound 3, half-maximal effective concentration: > 52000 nM
Compound 3 ended at the assay's limit (the forecaster's own chance of this, stated with the estimate: 60%); at least 1.2-fold (0.09 log units) between middle value and limit.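

Among the compounds shown here, compound 1, compound 2 and compound 3 all rest at a limit, not a number, in this assay, so no step among them can be read: the limit of > 52000 nM in this assay, at which 3 of the 3 values shown sit. The compounds shown leave open whether the group on the aromatic carbon affects the concentration needed at all.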